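The source may report more compounds than this note shows. Statements on the series, on what has been measured and on what is new or still open speak of the compounds shown alone.

The two measured compounds share one core and differ only in the saturated ring on the aromatic carbon. Compound 1 `CNC(=O)c1cc(Oc2ccc(Nc3nccc(N4CCCC4)n3)cc2)ccn1` carries pyrrolidin-1-yl, and in an assay on HEK293T cells for inhibition of nuclear factor NF-kappa-B complex (Homo sapiens), read by a luciferase reporter, with stated times of 6 h and 8 h (on this read-out higher numbers stand for weaker inhibition and lower numbers for stronger inhibition), compound 1 gives 3720 nM. For the measured compounds named here, compound 2 `CNC(=O)c1cc(Oc2ccc(Nc3nccc(N4CCCCC4)n3)cc2)ccn1` carries piperidin-1-yl, and in this assay compound 2 gives 840 nM, the lowest of the two numbers; the single measured step, a 4.4-fold lower number from compound 1 to compound 2 (0.65 log units; beyond the scatter), lies beyond the scatter. Compound 3 `CNC(=O)c1cc(Oc2ccc(Nc3nccc(N4CCc5ccccc5C4)n3)cc2)ccn1` has not yet been measured. It differs from compound 2 in one place: 1,2,3,4-tetrahydroisoquinolin-2-yl in place of piperidin-1-yl on an aromatic carbon. Going by the values given here, the only step that bears on this change is a 4.4-fold lower number from compound 1 to compound 2 (0.65 log units; beyond the scatter), where a larger saturated ring gave a lower number. Among the compounds with values here, the group entering in compound 3 is larger again, holding also one six-membered aromatic ring of carbon only, but no measured pair shows what such an added aromatic ring does, so the direction rests on one step alone. For compound 3 a lowering of similar or smaller size than the previous step is therefore expected, a 1.5-fold lower number from compound 2 to compound 3 (0.18 log units; within the scatter), with wide uncertainty. Compound 3 is estimated at 550 nM, between 150 nM and 2500 nM.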

Compound 3, half-maximal inhibitory concentration: 7780 nM
Compound 3: the middle estimate sits 14-fold (1.15 log units) below what was measured; the whole stated range lies below it.
By their numbers in this assay, from the lowest: compound 2; then compound 1; then compound 3.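

At this place on the six-membered aromatic ring with 2 nitrogen, a larger group does not keep lowering the number in this assay: where the earlier step, a 4.4-fold lower number from compound 1 to compound 2 (0.65 log units; beyond the scatter), pointed downward, 1,2,3,4-tetrahydroisoquinolin-2-yl in place of piperidin-1-yl reverses the direction, with a 9.3-fold higher number from compound 2 to compound 3 (0.97 log units; beyond the scatter). The entering group also stands on the weaker side of the smaller pyrrolidin-1-yl, with a 2.1-fold higher number from compound 1 to compound 3 (0.32 log units; beyond the scatter), so across these three compounds the number does not follow the size of the group, and piperidin-1-yl gives the lowest value. Nothing available explains this reversal.

The compounds shown leave open whether the higher number goes with the added six-membered aromatic ring of carbon only or with the larger group as a whole, a question on which azepan-1-yl or 4-phenylpiperidin-1-yl at this place would bear. They also leave open how a ring with a second hetero atom, such as morpholin-4-yl, or an open-chain amine, such as diethylamino, would compare with piperidin-1-yl.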